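The compounds below may be only part of what the source reports. "The series", "measured", "known", "first", "only" and "open" are said of these compounds alone.

In an ADME assay for permeability, using PAMPA (on this read-out lower numbers stand for lower permeability and higher numbers for higher permeability), compound 1 `NC(=O)c1cc(-c2ccccc2)cc2c(C3CCN(S(=O)(=O)CCCNC4CCCC4)CC3)c[nH]c12` gives 140 nm/s and compound 2 `NC(=O)c1cc(-c2ccccc2)cc2c(C3CCN(S(=O)(=O)CCCN4CCCCC4)CC3)c[nH]c12` gives 240 nm/s on a shared core. Compound 3 `NC(=O)c1cc(-c2ccccc2)cc2c(C3CCS(=O)(=O)CC3)c[nH]c12` carries a different group on that core and gives 277 nm/s as its reading, which lies within the usual scatter of both other compounds, so the three cannot be ranked.

The next compound to consider is compound 4 `NC(=O)c1cc(-c2ccc(F)cc2)cc2c(C3CCS(=O)(=O)CC3)c[nH]c12` which differs from compound 3 at a single place. The change is fluoro in place of hydrogen on an aromatic carbon and in words it is fluoro in place of hydrogen on an aromatic carbon, para to a large group, turning phenyl into 4-fluorophenyl.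

Among the compounds with values here, only one measured step is available, a 1.7-fold higher number from compound 1 to compound 2 (0.23 log units; within the scatter) and it stays within the scatter. That step swaps cyclopentylamino for piperidin-1-yl on a chain that neither compound 3 nor compound 4 carries, so it does not test a fluoro on the phenyl. With no direct evidence for this kind of change, the reading of compound 3 at 277 nm/s remains the best starting point, and no shift beyond the scatter is expected in this assay for this change. The expected size is a 1.0-fold higher number from compound 3 to compound 4 (0.02 log units; within the scatter) and that would be no real change. For compound 4 the estimated value is 290 nm/s with an expected range from 150 nm/s to 540 nm/s as the likely span.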

Compound 4, apparent permeability: 280 nm/s
Estimate against measurement, compound 4: 1.0-fold (0.02 log units) above; the measured number falls inside the stated range.
By their numbers in this assay, from the lowest: compounds 1, 2, 3 and 4 (each within the scatter of the next).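

In this assay, putting fluoro in place of hydrogen on an aromatic carbon, para to a large group, turns phenyl into 4-fluorophenyl and gives a 1.0-fold higher number from compound 3 to compound 4 (0.00 log units; within the scatter), so the two readings cannot be told apart. Within the data shown here, this is the first measured step on this ring: the only earlier step concerned cyclopentylamino and piperidin-1-yl on a chain that lies elsewhere on the molecule, and so it could say nothing about this position. For this one pair, then, a single fluorine at this place leaves the reading indistinguishable from that with hydrogen, though nothing available explains why the result came out this way.

This single pair cannot show whether a group other than fluoro at the same place, such as a carboxylic acid, an amine or trifluoromethyl, would also stay within the usual scatter of the hydrogen compound. It also leaves open whether the same fluoro would give a similar result on compound 1 or compound 2, which carry the longer sulfonyl chain with its amine.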